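Swapping the ring at the ester: phthalimide to phenyltriazole

The source may report more compounds than this note shows. Statements on the series, on what has been measured and on what is new or still open speak of the compounds shown alone.

Compound 1 `O=C(OCC1CCCN(CCCc2ccccc2)C1)c1ccccc1C(F)(F)F` was tested in an in vitro functional assay on HEK ts201 cells for antagonist activity at Neuronal acetylcholine receptor; alpha4/beta2 (Homo sapiens), read by fluorescence and calcium flux (a higher number here means a weaker inhibitor, a lower number a stronger inhibitor), where compound 1 gives 7940 nM; 8000 nM (2 entries). The two entries for compound 1 agree closely, as the record shows: the several entries of compound 1 in this assay, 7940 nM; 8000 nM (2 entries). Compound 2 `O=C(OCC1CCCN(CCCc2ccccc2)C1)c1ccccc1N1C(=O)c2ccccc2C1=O` carries a different group on the ester-bearing ring, and in this assay compound 2 gives 5010 nM. That is the only number shown for compound 2; a further entry exists without a single number. Both compounds are weak inhibitors, and their values lie within the usual scatter of each other, so no ordering between them can be claimed.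

Compound 3 `O=C(OCC1CCCN(CCCc2ccccc2)C1)c1ccccc1-n1cc(-c2ccccc2)nn1` is not yet measured. It differs from compound 2 in one place: a group of 11 heavy atoms (8 carbon, 3 nitrogen; one five-membered aromatic ring with 3 hetero atoms, one six-membered aromatic ring of carbon only) in place of a group of 11 heavy atoms (8 carbon, 1 nitrogen, 2 oxygen; one five-membered non-aromatic ring with 1 hetero atom, one six-membered aromatic ring of carbon only), on an aromatic carbon. For the measured compounds named here, no measured step in this assay connects compound 2 to any neighbour, so the size of this kind of change is unknown here. Given the weak and similar values of compound 1 and compound 2, the expectation is that compound 3 stays in the same weak region, with a step of a 1.1-fold lower number from compound 2 to compound 3 (0.05 log units; within the scatter) that is expected to fall within the scatter. In this assay compound 3 is estimated at 4500 nM, with a range from 1500 nM to 13000 nM.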

Compound 3, half-maximal inhibitory concentration: 2820 nM
Beside the measured number, compound 3's estimate is 1.6-fold (0.20 log units) above it; measured number inside the range.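

For the compounds shown here, this is the only step in this assay that can be read at this position, on an aromatic carbon ortho to a large group: placing 4-phenyl-1H-1,2,3-triazol-1-yl there in exchange for the group carried by compound 2 gives a 1.8-fold lower number from compound 2 to compound 3 (0.25 log units; within the scatter). The two groups match in heavy-atom count and each holds a six-membered aromatic ring of carbon only, but they differ in their five-membered ring, which is aromatic in one and non-aromatic in the other, and in the two double bonds outside aromatic rings that only the departing group has, so this sizeable change in structure leaves no difference that can be told from the scatter. For a sense of how closely repeated readings can sit in this assay, the record of compound 1 offers one example: the several entries of compound 1 in this assay, 7940 nM; 8000 nM (2 entries)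

Going by these compounds, what an amine or a carboxylic acid would do at this same aromatic carbon remains open, as does the effect of a much smaller group such as a single fluorine atom. A single step also cannot show whether any group at this position can move the number beyond the scatter in either direction.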